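A few compounds are considered here, and "the series" means these few. Any claim that something is new, unique, unknown or untested is made for them only; others in the source may bear on it.

Measured compounds in an assay on HEK293 cells for agonist activity at transient receptor potential cation channel subfamily M member 8 (Homo sapiens), read by fluorescence and calcium flux, with a stated time of 15 min; on this read-out lower numbers stand for an effect already at smaller amounts and higher numbers for an effect only at larger amounts of compound:
compound 1, `CCN(Cc1cccs1)C(=O)COc1ccc(C)cc1`, gives 8 nM;
compound 2, `CCc1ccc(OCC(=O)N(CC)Cc2cccs2)cc1`, gives 67 nM;
compound 3, `CCN(Cc1cccs1)C(=O)COc1ccc(C(C)C)cc1`, gives 397 nM.

Compound 3 stands at the highest number of the three, and both of its steps lie beyond the scatter: there is a 5.9-fold higher number from compound 2 to compound 3 (0.77 log units; beyond the scatter) and a 50-fold higher number from compound 1 to compound 3 (1.70 log units; beyond the scatter). The third step in the set is an 8.4-fold higher number from compound 1 to compound 2 (0.92 log units; beyond the scatter). All three steps add carbon at the same place on the shared core, and each addition raised the number.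

Compound 4, `CCN(Cc1cccs1)C(=O)COc1ccc(C#N)cc1`, differs from compound 3 in one place: cyano in place of isopropyl on an aromatic carbon. Among the measured compounds shown here, no measured step brings in a cyano, so the data say nothing direct about this group. What bears on the change is the direction seen in compound 1 and compound 2, where less carbon at this position went with lower numbers, as in a 50-fold higher number from compound 1 to compound 3 (1.70 log units; beyond the scatter) and a 5.9-fold higher number from compound 2 to compound 3 (0.77 log units; beyond the scatter). Because the additions of carbon gave a 50-fold higher number from compound 1 to compound 3 (1.70 log units; beyond the scatter) and a 5.9-fold higher number from compound 2 to compound 3 (0.77 log units; beyond the scatter) while the change to compound 4 removes carbon rather than adding it, compound 4 is expected to give a lower number than compound 3, with an expected step of a 9.9-fold lower number from compound 3 to compound 4 (1.00 log units; beyond the scatter). The estimate for compound 4 in this assay is 40 nM. The expected range runs from 8 nM to 200 nM, kept wide since a cyano at this position has not been measured.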

Compound 4, half-maximal effective concentration: 1990 nM
Compound 4: middle estimate off by 50-fold (1.70 log units), on the low side, outside the stated range (above it).
By their numbers in this assay, from the lowest: compound 1; then compound 2; then compound 3; then compound 4.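

In this assay the change to cyano takes carbon away from this aromatic carbon, and the number still climbs (a 5.0-fold higher number from compound 3 to compound 4 (0.70 log units; beyond the scatter)), so compound 4 goes against the link between carbon and number that compounds 1, 2 and 3 suggested. The gap widens against the smaller alkyl groups (a 30-fold higher number from compound 2 to compound 4 (1.47 log units; beyond the scatter)) and (a 250-fold higher number from compound 1 to compound 4 (2.40 log units; beyond the scatter)), which puts compound 4 at the highest number of the four and leaves compound 1 with its methyl at the lowest, with every one of these steps beyond the scatter. Cyano also brings a triple bond and a hydrogen-bond acceptor that isopropyl does not have, but nothing available here shows what lies behind the higher number.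

The compounds shown leave open whether methyl marks a narrow optimum at this position or whether other small groups, such as chloro, methoxy or a plain hydrogen, would also stay near compound 1. They also do not settle whether another group with a triple bond, such as ethynyl, would land close to compound 4.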